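The compounds below may be only part of what the source reports. "The series", "measured", "known", "first", "only" and "open" are said of these compounds alone.

Compound 1 `COc1ccc(-n2c(SCc3ccc(C)cc3)nnc2-c2cc(OC)c(OC)c(OC)c2)cc1` gives 56500 nM in a functional assay on PC-3 cells (Homo sapiens) for inhibition, read by MTT assay, with a stated time of 48 h; a higher number here means a weaker inhibitor, a lower number a stronger inhibitor.
Compound 2 `COc1ccc(-n2c(SCC(=O)c3ccc4ccccc4c3)nnc2-c2cc(OC)c(OC)c(OC)c2)cc1` gives a limit of this assay rather than a number, > 60000 nM.
Compound 3 `COc1cc(-c2nnc(SCc3ccc(C)cc3)n2-c2ccc(N(C)C)cc2)cc(OC)c1OC` gives 37300 nM in this assay.

Compound 3 holds the lowest of the two numbers shown, yet the nearest value sits within the scatter, a 1.5-fold lower number from compound 1 to compound 3 (0.18 log units; within the scatter), so no order between them can be read. All three share the same core and differ only in the group on the saturated chain carbon bound to a sulfur or on the aromatic carbon of the anilino ring.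

The unmeasured compound 4 `COc1cc(-c2nnc(SCC(=O)Nc3ccc(Cl)cc3)n2-c2ccc(N(C)C)cc2)cc(OC)c1OC` departs from compound 3 at the first of these places: (4-chlorophenyl)carbamoyl in place of 4-methylphenyl on a saturated chain carbon bound to a sulfur. For the measured compounds named here, the one measured step at the same place is an at least 1.0-fold higher number from compound 1 to compound 2 (0.02 log units; that floor lies within the scatter), where a carbonyl-bearing group replaced the 4-methylphenyl and the read-out reached only a limit, as told by the limit of > 60000 nM in this assay, at which 1 of the 3 values shown sits. That step offers no sign of a lower number and leaves open a higher one. On this basis the expectation for this assay is a 1.6-fold higher number from compound 3 to compound 4 (0.21 log units; within the scatter), with a fair chance that compound 4 returns only a limit.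

The estimate for compound 4 in this assay is 60000 nM, expected between 30000 nM and 120000 nM.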

Compound 4, half-maximal inhibitory concentration: > 60000 nM
Compound 4 ended at the assay's limit; the forecaster's own chance of this, stated with the estimate: 45%; the middle value sits exactly at the limit.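

Moving from 4-methylphenyl to (4-chlorophenyl)carbamoyl on a saturated chain carbon bound to a sulfur, with dimethylamino on the aromatic carbon, reads in this assay as an at least 1.6-fold higher number from compound 3 to compound 4 (0.20 log units; that floor lies within the scatter), so this step gives a floor and not a size, and no change can be claimed from it. Compound 4 gives > 60000 nM, which is a limit of the assay and not a number. Carbonyl-bearing replacements of 4-methylphenyl at this place have now reached the limit with both methoxy and dimethylamino on the aromatic carbon, while among the compounds shown only the 4-methylphenyl compounds, compound 1 and compound 3, return numbers: the limit of > 60000 nM in this assay, at which 2 of the 4 values shown sit.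

As far as these compounds go, how far compound 2 and compound 4 lie past the limit remains unknown, so no order can be read between them or against the numbers of the other two compounds. From the compounds shown here alone, it also remains open whether the limit goes with the carbonyl or with the aromatic group beyond it, and a carboxylic acid or a simple amine on the same saturated chain carbon would help to separate the two.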